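Swapping the Tetrazole Ring for an Imidazole Ring

The source may report more compounds than this note shows. Statements on the series, on what has been measured and on what is new or still open speak of the compounds shown alone.

Of the compounds shown here, three sharing one core have been tested in an assay on CHO cells for displacement of a labelled ligand from adenosine receptor A3 (Homo sapiens), read by scintillation counting, with a stated time of 120 min, tested at 1 uM; a lower number here means less inhibition, a higher number more inhibition at the concentration tested (going by the name of the read-out). Compound 1 `N#Cc1c(N)nc(SCc2cccc(C(N)=O)c2)c(C#N)c1-c1ccc(OCC2CC2)cc1` gives 1%, compound 2 `N#Cc1c(N)nc(SCc2nnn[nH]2)c(C#N)c1-c1ccc(OCC2CC2)cc1` gives 1%, and compound 3 `N#Cc1c(N)nc(SCc2ccn[nH]2)c(C#N)c1-c1ccc(OCC2CC2)cc1` gives 6%. Among the measured compounds shown here, compound 2 stands level with compound 1, the two together being the lowest of the three numbers, while compound 3 sits only slightly apart: a number 5 percentage points higher from compound 2 to compound 3 (within the scatter), and likewise no change at the digits printed from compound 1 to compound 2 (within the scatter) and a number 5 percentage points higher from compound 1 to compound 3 (within the scatter), so none of the measured steps reaches beyond the scatter.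

Compound 4 `N#Cc1c(N)nc(SCc2cnc[nH]2)c(C#N)c1-c1ccc(OCC2CC2)cc1` differs from compound 2 in one place: 1H-imidazol-5-yl in place of 1H-tetrazol-5-yl on a saturated chain carbon bound to a sulfur. The step that bears most on this is the earlier exchange of one five-membered aromatic ring for another on the same saturated chain carbon, from compound 2 to compound 3, which stayed within the scatter, as did the exchange of the larger aromatic group from compound 1 to compound 2. A step of no real size in this assay is therefore expected, a number 2 percentage points higher from compound 2 to compound 4 (within the scatter). Compound 4 is estimated at 3%, within a range from 0% to 12%.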

Compound 4, a percentage reported as inhibition, at one concentration (the size of the read-out at that concentration, not a potency): 1%
For compound 4 the middle estimate is 2 percentage points above the measured one, within the range that was stated.
By their numbers in this assay, from the lowest: compounds 1, 2, 4 and 3 (each within the scatter of the next).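

In this assay, 1H-imidazol-5-yl in this place gives no change at the digits printed from compound 2 to compound 4 (within the scatter) and no change at the digits printed from compound 1 to compound 4 (within the scatter) and also a number 5 percentage points lower from compound 3 to compound 4 (within the scatter) in the comparison with the other five-membered ring. All four numbers now lie within the scatter of one another, so a ring with 2 hetero atoms cannot be told apart from one with 4 hetero atoms, nor from the larger 3-carbamoylphenyl group, at this single concentration. No supporting information is available to explain this flat result.

On these data alone, whether any group on the saturated chain carbon bound to a sulfur can move the number clear of the scatter remains open. A carboxylic acid, an amine or a longer chain in place of the ring would test this, since the groups shown here are all aromatic rings.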